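A few compounds are considered here, and "the series" means these few. Any claim that something is new, unique, unknown or untested is made for them only; others in the source may bear on it.

Values in an ADME assay on MRC5 cells (Homo sapiens) for cytotoxicity, read by fluorescence and resazurin assay, with a stated time of 3 days; a lower number here means a stronger inhibitor, a higher number a weaker inhibitor (lower means stronger):
- Compound 1 (`Cc1cn(C2CCN(Cc3cccc(OC4CCCC4)c3)CC2)c(=O)[nH]c1=O`) gives 30300 nM
- Compound 2 (`Cc1ccc(Oc2cccc(CN3CCC(n4cc(C)c(=O)[nH]c4=O)CC3)c2)cc1`) gives > 64000 nM (a limit of the assay, not a number)
- Compound 3 (`Cc1cn(C2CCN(Cc3cccc(Oc4cc(Cl)cc(Cl)c4)c3)CC2)c(=O)[nH]c1=O`) gives 6730 nM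

Of the two actual numbers, compound 1 holds the higher, and compound 3 is its nearest neighbour, with a 4.5-fold lower number from compound 1 to compound 3 (0.65 log units; beyond the scatter).

Compound 4 (`Cc1cn(C2CCN(Cc3cccc(Oc4ccc(F)c(F)c4)c3)CC2)c(=O)[nH]c1=O`) carries 3,4-difluorophenyl in place of cyclopentyl on an oxygen on an aromatic ring.

Two measured swaps of the same kind bear on this and point in opposite directions: a 4.5-fold lower number from compound 1 to compound 3 (0.65 log units; beyond the scatter) and an at least 2.1-fold higher number from compound 1 to compound 2 (0.32 log units; beyond the scatter). A small downward move is therefore expected, and it may not clear the scatter. The estimated change is a 1.7-fold lower number from compound 1 to compound 4 (0.23 log units; within the scatter). For compound 4 the estimate is 18000 nM, with an expected range of 6000 nM to 50000 nM.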

Compound 4, half-maximal inhibitory concentration: > 64000 nM
Compound 4 was reported as a limit; the forecaster's own chance of this, stated with the estimate: 12%; at least 3.5-fold (0.55 log units) between middle value and limit.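

In this assay compound 4 is reported only as a limit of the assay, and that limit recurs in this small set: the limit of > 64000 nM in this assay, at which 2 of the 4 values shown sit.

Replacing cyclopentyl on this oxygen with 3,4-difluorophenyl gives an at least 2.1-fold higher number from compound 1 to compound 4 (0.32 log units; beyond the scatter), while replacing 3,5-dichlorophenyl with 3,4-difluorophenyl gives an at least 9.5-fold higher number from compound 3 to compound 4 (0.97 log units; beyond the scatter). An aromatic ring on this oxygen therefore does not fix the direction of change: relative to compound 1, compound 2 and compound 4 rise, whereas compound 3 goes against them and falls.

The step between compound 2 and compound 4 cannot be read, as both values are limits. Going by these compounds, how an aminophenyl or carboxyphenyl group on this oxygen would read remains open.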